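A few compounds are considered here, and "the series" means these few. Any claim that something is new, unique, unknown or untested is made for them only; others in the source may bear on it.

Of the compounds shown here, three have been measured in a functional assay on the whole organism (artery, strain albino) with Rattus norvegicus as the target, with a stated time of 180 min, at a dose of 10 mg/kg by the oral route; on this read-out higher numbers stand for more inhibition at the one dose given (going by the name of the read-out) and lower numbers for less inhibition. Compound 1 `CC1=C(C(=O)Nc2ccc(Br)cc2)C(c2ccc(Cl)cc2Cl)N=C(SCc2cccc(Cl)c2)N1` gives 11.9%. Compound 2 `COc1ccc(C2N=C(SCc3ccccc3)NC(C)=C2C(=O)Nc2ccc(Br)cc2)cc1` gives 10.3%, and compound 3 `COc1ccc(C2N=C(SCc3ccccc3Cl)NC(C)=C2C(=O)Nc2ccc(Br)cc2)cc1` gives 11.3%. All three numbers lie within the usual scatter of one another, so compound 3 cannot be ranked against compound 1 or compound 2; its number simply sits alongside theirs.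

Compound 4 `COc1ccc(C2N=C(SCc3cccc(Cl)c3)NC(C)=C2C(=O)Nc2ccc(Br)cc2)cc1` differs from compound 3 in one place: 3-chlorophenyl in place of 2-chlorophenyl on a saturated chain carbon bound to a sulfur. The chlorine stays on the same benzyl group bound to sulfur, only its position on that ring is changed.

For the measured compounds named here, only one measured step touches this part of the molecule, and it concerns adding a chlorine rather than moving one: a number 1 percentage points higher from compound 2 to compound 3 (within the scatter). Beyond that, compound 1 carries a 3-chlorobenzyl group on sulfur, as compound 4 will, yet compound 1 also differs from compound 3 elsewhere, so its number and that of compound 3 only show that the two lie within the scatter of each other.

On this evidence no step beyond the scatter is expected from compound 3 to compound 4, that is a number 0.2 percentage points higher from compound 3 to compound 4 (within the scatter). Compound 4 is therefore estimated to give 11.5% in this assay , with a likely range from 4% to 19%.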

Compound 4, a percentage reported as inhibition, in the whole organism at one dose (the size of the read-out at that dose, not a potency): 27.3%
For compound 4 the middle estimate is 15.8 percentage points below the measured one; measured number outside the range, above it.
By their numbers in this assay, from the lowest: compounds 2, 3 and 1 (each within the scatter of the next); then compound 4.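

In this assay, the place of the chlorine on the benzyl group bound to sulfur matters: 3-chlorophenyl in place of 2-chlorophenyl on that saturated chain carbon gives a number 16 percentage points higher from compound 3 to compound 4 (beyond the scatter). The same change, chloro in place of hydrogen on an aromatic carbon, therefore reads differently in these two cases, with a number 1 percentage points higher from compound 2 to compound 3 (within the scatter) for the 2-chlorobenzyl group but a number 17 percentage points higher from compound 2 to compound 4 (beyond the scatter) for the 3-chlorobenzyl group. The 3-chlorobenzyl group is not enough on its own, since compound 1 carries it too, and 4-methoxyphenyl in place of 2,4-dichlorophenyl on a saturated ring carbon gives a number 15.4 percentage points higher from compound 1 to compound 4 (beyond the scatter), so the higher number appears here only when the 3-chlorobenzyl and 4-methoxyphenyl groups occur together.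

No measurement shown explains why moving the chlorine changes the number. Going by these compounds, it remains open whether a 4-chlorobenzyl group would match compound 4, and whether a methyl group or an amine in place of the chlorine on the benzyl ring would keep the number of compound 4.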